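Chloro in place of methyl: from compound 2 to compound 3

The compounds below may be only part of what the source reports. "The series", "measured", "known", "first", "only" and "open" are said of these compounds alone.

Compound 2 `Cc1ccc(-c2cc3n(n2)CCN(C(=O)c2ccccc2)C3)nc1` gives 244 nM in a functional assay on HEK293 cells for negative allosteric modulation of metabotropic glutamate receptor 5 (Homo sapiens), read by calcium flux, with a stated time of 20 min; on this read-out lower numbers stand for stronger inhibition and higher numbers for weaker inhibition. Among the measured compounds shown here, this is the lowest of the two numbers so far. The other measured member, compound 1 `Cc1ccnc(-c2cc3n(n2)CCN(C(=O)c2ccccc2)C3)c1`, gives 451 nM in this assay. For the measured compounds named here, the single measured step, a 1.8-fold lower number from compound 1 to compound 2 (0.27 log units; within the scatter), lies within the scatter, so the two measured compounds cannot be put in order on this read-out.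

Compound 3 `O=C(c1ccccc1)N1CCn2nc(-c3ccc(Cl)cn3)cc2C1` is not yet measured. It differs from compound 2 by chloro in place of methyl on an aromatic carbon. Going by the values given here, the one measured step concerns where the methyl sits on the same ring, not its exchange for another group; no measured pair shows methyl against chloro. Among the compounds with values here, no step therefore bears directly on this change. The expectation rests only on the character of the change: one heavy atom for one heavy atom at the same place, with no change in ring count, donors, acceptors or charge, which is expected to give a step no larger than the scatter. Compound 3 is expected near 220 nM, in the range 80 nM to 600 nM, an expected step of a 1.1-fold lower number from compound 2 to compound 3 (0.04 log units; within the scatter).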

Compound 3, half-maximal inhibitory concentration: 201 nM
Estimate against measurement, compound 3: 1.1-fold (0.04 log units) above; low and high end bracket the measured number.
By their numbers in this assay, from the lowest: compounds 3, 2 and 1 (each within the scatter of the next, the first and the last beyond it).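

In this assay, the exchange of the group itself at this place, on an aromatic carbon two atoms from the ring nitrogen and para to a large group, gives a 1.2-fold lower number from compound 2 to compound 3 (0.08 log units; within the scatter), so 5-chloropyridin-2-yl and 5-methylpyridin-2-yl cannot be put in order on this read-out. The series now also holds its first step beyond the scatter, a 2.2-fold lower number from compound 1 to compound 3 (0.35 log units; beyond the scatter), although it is modest, and because both the group and its place differ in that step, it cannot be assigned to either difference alone. No measurement available here offers an explanation for either step.

The compounds shown leave open how this place responds to a group other than methyl or chloro, such as an amine, a carboxylic acid or a longer chain such as propyl, since two small groups with one heavy atom each say little about larger or charged ones. Going by these compounds, the phenyl ring on the carbonyl is also the same in all three compounds, so the effect of a fluoro or methoxy group on that ring remains unknown, as does whether it would add to the 5-chloropyridin-2-yl change.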